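Notes on a dichlorophenyl isomer

The compounds below may be only part of what the source reports. "The series", "measured", "known", "first", "only" and "open" are said of these compounds alone.

Values in a functional assay on MCF7 cells (Homo sapiens) for antiproliferative activity, read by MTT assay; a higher number here means a weaker inhibitor, a lower number a stronger inhibitor:
Compound 1 `COc1ccc(-c2ccnc(Nc3ccc([N+](=O)[O-])cc3)n2)cc1`: 770 nM
Compound 2 `O=[N+]([O-])c1ccc(Nc2nccc(-c3ccc(Cl)c(Cl)c3)n2)cc1`: 3510 nM
Compound 3 `O=[N+]([O-])c1ccc(Nc2nccc(-c3ccc(Cl)cc3Cl)n2)cc1`: not yet measured

Of the two measured compounds, compound 2 has the higher number in this assay, at 3510 nM, which makes it the weaker inhibitor. The next change is 2,4-dichlorophenyl in place of 3,4-dichlorophenyl on an aromatic carbon, the same atoms joined differently. Going by the values given here, the only measured step that bears on it is a 4.6-fold higher number from compound 1 to compound 2 (0.66 log units; beyond the scatter). That modest step exchanged 4-methoxyphenyl for 3,4-dichlorophenyl, a change of group rather than a rearrangement of the same atoms. Among the compounds with values here, no measured pair tests where the chlorines sit, so the data give no direction. A shift within the scatter is therefore expected in this assay. The expected step is a 1.2-fold lower number from compound 2 to compound 3 (0.07 log units; within the scatter). For compound 3 the estimated value is 3000 nM, with an expected range of 1000 nM to 9000 nM.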

Compound 3, half-maximal inhibitory concentration: 192000 nM
Beside the measured number, compound 3's estimate is 64-fold (1.81 log units) below it, outside the stated range (above it).
By their numbers in this assay, from the lowest: compound 1; then compound 2; then compound 3.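

In this assay, where the two chlorines sit on this phenyl group proves decisive: 2,4-dichlorophenyl in place of 3,4-dichlorophenyl gives a 55-fold higher number from compound 2 to compound 3 (1.74 log units; beyond the scatter), although the counts of heavy atoms, donors and acceptors in the group stay the same. Against 4-methoxyphenyl, 2,4-dichlorophenyl gives a 250-fold higher number from compound 1 to compound 3 (2.40 log units; beyond the scatter), a large step where 3,4-dichlorophenyl gave only a modest one, so the effect of a dichlorophenyl group at this carbon depends on the arrangement of its chlorines. No evidence is at hand that accounts for the step between the two isomers.

The compounds shown leave open whether a single chlorine on the phenyl group would give a step of similar size. Also open, as far as these compounds go, is whether methyl groups or fluorines in place of the two chlorines would show the same dependence on arrangement.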